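The source may hold more compounds than are shown below. What is called first, only, known or untested is meant among the compounds shown, and "the series" means these compounds.

Measured in a functional assay on MGC-803 cells (Homo sapiens) for inhibition, read by sulforhodamine B assay; a lower number here means a stronger inhibitor, a higher number a weaker inhibitor:
Compound 1 `O=C1C=C(Nc2ccccc2F)C(=O)c2c1nc1n2[C@H]2OC[C@@H](O)[C@H]2OC1`: 2080 nM
Compound 2 `O=C1C=C(NC2CCCCC2)C(=O)c2c1nc1n2[C@H]2OC[C@@H](O)[C@H]2OC1`: > 8000 nM, a limit of the assay
Compound 3 `COc1ccc(NC2=CC(=O)c3nc4n(c3C2=O)[C@H]2OC[C@@H](O)[C@H]2OC4)cc1`: 1680 nM

Among the measured compounds shown here, the two actual numbers stand close, with a 1.2-fold lower number from compound 1 to compound 3 (0.09 log units; within the scatter), so compound 3 sits level with the only other compound that has a number. Compound 4 `O=C1C=C(N2CCCCC2)C(=O)c2c1nc1n2[C@H]2OC[C@@H](O)[C@H]2OC1` carries piperidin-1-yl in place of (4-methoxyphenyl)amino on a double-bonded ring carbon. For the measured compounds named here, two measured steps bear on this change, an at least 3.8-fold higher number from compound 1 to compound 2 (0.58 log units; beyond the scatter) and an at least 4.7-fold lower number from compound 2 to compound 3 (0.67 log units; beyond the scatter), and each separates a non-aromatic ring from an aromatic one. A rise of similar size is therefore expected, beyond the scatter: a 4.2-fold higher number from compound 3 to compound 4 (0.62 log units; beyond the scatter). Compound 4 is estimated at 7000 nM, within 2500 nM to 20000 nM. The assay may report only a limit for it.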

Compound 4, half-maximal inhibitory concentration: > 8000 nM
Compound 4 was reported as a limit; the forecaster's own chance of this, stated with the estimate: 50%; at least 1.1-fold (0.05 log units) between middle value and limit.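

Compound 4 gives only a limit of the assay in this assay. With piperidin-1-yl on the double-bonded ring carbon, the data show an at least 4.7-fold higher number from compound 3 to compound 4 (0.67 log units; beyond the scatter) and an at least 3.8-fold higher number from compound 1 to compound 4 (0.58 log units; beyond the scatter). The non-aromatic ring thus falls short of both aromatic amines with or without the amine hydrogen, which compound 2 keeps and compound 4 lacks, and the step between these two cannot be read: the limit of > 8000 nM in this assay, at which 2 of the 4 values shown sit.

On these data alone, how far compound 2 and compound 4 lie past that limit stays open. So does whether a benzylamino group or an open-chain butylamino group would give a readable number.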